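This account rests on a few compounds, and the source may have more. Where it says the series, first, only, none or still open, it means among the compounds named here.

Compound 1 `O=C(Nc1ccc(Cl)c(-c2nnc3c(Cl)cccn23)c1)c1ccc(C(F)(F)F)cc1Cl` is an amide built on a shared core. In a functional assay on MCF7 cells (Homo sapiens) for antiproliferative activity, read by MTT assay, with a stated time of 72 h (on this read-out lower numbers stand for stronger inhibition and higher numbers for weaker inhibition), compound 1 gives 81600 nM, the highest of the two numbers shown, though the gap to its neighbour is within the scatter. Compound 2 `O=C(Nc1ccc(Cl)c(-c2nnc3c(Cl)cccn23)c1)c1ccc(Cl)cc1Cl` carries chloro in place of trifluoromethyl on an aromatic carbon, and in this assay compound 2 gives 78200 nM, so that exchange produced a 1.0-fold lower number from compound 1 to compound 2 (0.02 log units; within the scatter). Compound 3 `O=C(Nc1ccc(Cl)c(-c2nnc3c(Cl)cccn23)c1)c1cccnc1Cl` has 2-chloropyridin-3-yl in place of 2,4-dichlorophenyl on the carbonyl carbon. In this assay compound 3 gives > 100000 nM, which is a limit of the assay rather than a number. The change gave an at least 1.2-fold higher number from compound 2 to compound 3 (0.10 log units; that floor lies within the scatter), ending at the limit of > 100000 nM in this assay, at which 1 of the 3 values shown sits, so its true size cannot be read.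

Compound 4 `O=C(Nc1ccc(Cl)c(-c2nnc3c(Cl)cccn23)c1)c1ccccc1Cl` differs from compound 1 by hydrogen in place of trifluoromethyl on an aromatic carbon. The step that bears on it is the exchange at the same aromatic carbon, which gave a 1.0-fold lower number from compound 1 to compound 2 (0.02 log units; within the scatter) and left the number where it was. A swap to hydrogen there is expected to move the number no further than the scatter, so the expected step is a 1.1-fold higher number from compound 1 to compound 4 (0.04 log units; within the scatter). Compound 4 is therefore estimated at 90000 nM, with a range from 40000 nM to 200000 nM, and a real chance that only a limit is reported.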

Compound 4, half-maximal inhibitory concentration: 92200 nM
The estimate for compound 4 lay 1.0-fold (0.01 log units) below the measured number; measured number inside the range.
By their numbers in this assay, from the lowest: compounds 2, 1 and 4 (each within the scatter of the next). At a limit, above all of these: compound 3.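

Compound 4 has no substituent at all on this aromatic carbon, and the step to hydrogen gives a 1.1-fold higher number from compound 1 to compound 4 (0.05 log units; within the scatter) in this assay. The same carbon carrying hydrogen in place of chloro gives a 1.2-fold higher number from compound 2 to compound 4 (0.07 log units; within the scatter), so trifluoromethyl, chloro and hydrogen in compounds 1, 2 and 4 cannot be told apart in this assay, and a bare carbon does no differently from a substituted one. Compound 3 stands at a limit of the assay, so the true size of its step to compound 4 cannot be read: the limit of > 100000 nM in this assay, at which 1 of the 4 values shown sits. The exchange of 2-chloropyridin-3-yl for 2-chlorophenyl on the carbonyl carbon gives an at least 1.0-fold lower number from compound 3 to compound 4 (0.03 log units; that floor lies within the scatter) as a floor only.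

Going by these compounds, it remains open whether any group on this carbon can separate itself from these three, for example an amine, a carboxylic acid or a longer chain. On these data alone, the chloro group on the same ring also stays the same in compounds 1, 2 and 4, so what a change there would do is unknown.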